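The source may hold more compounds than are shown below. What is called first, only, known or untested is meant among the compounds shown, and "the series" means these compounds.

Compound 1 `O=C(Nc1ccc(Oc2ccnc3[nH]ccc23)cc1)c1cc2cccnc2n(-c2ccc(Br)cc2F)c1=O` is the starting point of this series. In a functional assay on A549 cells (Homo sapiens) for antiproliferative activity, read by MTT assay, with a stated time of 72 h (a higher number here means a weaker inhibitor, a lower number a stronger inhibitor), compound 1 gives 1570 nM. Compound 2 `O=C(Nc1ccc(Oc2ccnc3[nH]ccc23)c(F)c1)c1cc2cccnc2n(-c2ccc(Br)cc2F)c1=O` differs from it in one place, (fluoro in place of hydrogen on an aromatic carbon), and in this assay compound 2 gives 460 nM; the change brings a 3.4-fold lower number from compound 1 to compound 2 (0.53 log units; beyond the scatter).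

Compound 3 `Cn1ccc2c(Oc3ccc(NC(=O)c4cc5cccnc5n(-c5ccccc5)c4=O)cc3)ccnc21` carries a different core, and the difference between the two cores is not broken down here. In this assay compound 3 gives 850 nM, a number that lies within the usual scatter of both compound 1 and compound 2, so nothing can be said about order among these three.

Compound 4 `Cn1ccc2c(Oc3ccc(NC(=O)c4cc5cccnc5n(-c5ccc(F)cc5)c4=O)cc3)ccnc21` is the compound still to be measured. Relative to compound 3 it carries fluoro in place of hydrogen on an aromatic carbon. For the measured compounds named here, this is the same kind of change as the one from compound 1 to compound 2, but not the same: in the earlier pair the fluorine sits ortho to a large group and meta to a large group, whereas in compound 4 it sits para to a large group, on the phenyl that becomes 4-fluorophenyl. Going by the values given here, because the only guide is a 3.4-fold lower number from compound 1 to compound 2 (0.53 log units; beyond the scatter), made at a different place, the step from compound 3 to compound 4 is expected to be smaller, a 1.4-fold lower number from compound 3 to compound 4 (0.15 log units; within the scatter), with wide uncertainty. For compound 4 in this assay the estimate is 600 nM, with a likely range from 250 nM to 1500 nM.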

Compound 4, half-maximal inhibitory concentration: 210 nM
Compound 4: the middle estimate sits 2.9-fold (0.46 log units) above what was measured, outside the stated range (below it).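

In this assay, the change from phenyl to 4-fluorophenyl, with the fluoro para to a large group, brings a 4.0-fold lower number from compound 3 to compound 4 (0.61 log units; beyond the scatter). Set beside the earlier step, the same kind of replacement goes with a lower number of like size on both cores: the same change on two cores in this assay, a 3.4-fold lower number (0.53 log units; beyond the scatter) from compound 1 to compound 2 and a 4.0-fold lower number (0.61 log units; beyond the scatter) from compound 3 to compound 4, 1.2-fold (0.07 log units) apart, within the scatter of two such steps This shows that, in these two pairs, the step carries over from one core to the other with its size kept, but it gives no general rule for the series: there are only two pairs, the fluoro stands at a different place in each, and the data do not say why the two steps agree.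

The compounds shown leave open whether a step of this size would also appear with chloro, methyl or methoxy on the same carbon, and whether the fluoro of compound 2 and the fluoro of compound 4 would add up when placed together in one molecule. They also leave open what an amine or a carboxylic acid at that place on the phenyl would do, and whether the agreement between the two steps holds in any read-out other than this assay.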